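The compounds below may be only part of what the source reports. "The series", "measured", "known", "first", "only" and "open" are said of these compounds alone.

Compound 1 `COc1ccccc1C(=O)NC(=S)NNc1ncnc2ccccc12` in a functional assay on KB cells (Homo sapiens) for cytotoxicity, read by MTT assay, with a stated time of 72 h (a lower number here means a stronger inhibitor, a higher number a weaker inhibitor), gives > 50000 nM, a limit of the assay. Compound 2 `O=C(NC(=S)NNc1ncnc2ccccc12)c1ccccc1` gives 2330 nM.

Compound 2 thus holds the only number shown; the other value is a limit. The step of an at least 21-fold lower number from compound 1 to compound 2 (1.33 log units; beyond the scatter), hydrogen in place of methoxy on an aromatic carbon, is large. Compound 3 `O=C(NC(=S)NNc1ncnc2ccccc12)c1ccc(Cl)cc1` differs from compound 2 by chloro in place of hydrogen on an aromatic carbon. Within the data shown here, no measured step concerns a chloro group, so the measured step offers no direct guide. The change from compound 2 to compound 3 is expected to be a 1.3-fold lower number from compound 2 to compound 3 (0.11 log units; within the scatter), within the scatter. Compound 3 is therefore estimated at 1800 nM, between 600 nM and 6000 nM.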

Compound 3, half-maximal inhibitory concentration: 3940 nM
The estimate for compound 3 lay 2.2-fold (0.34 log units) below the measured number, and the stated range covers the measured number.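

Placing chloro on an aromatic carbon para to a large group gives a 1.7-fold higher number from compound 2 to compound 3 (0.23 log units; within the scatter), so in this assay this position tolerates the change without a shift beyond the scatter. Replacing 2-methoxyphenyl with 4-chlorophenyl gives an at least 12-fold lower number from compound 1 to compound 3 (1.10 log units; beyond the scatter), so compound 3, like compound 2, stands clear of compound 1. The value of compound 1 is a limit of the assay, not a number: the limit of > 50000 nM in this assay, at which 1 of the 3 values shown sits.

The compounds shown leave open how an amine or a carboxylic acid on that same carbon would read. They also leave open whether chloro elsewhere on the ring would match compound 3.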